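The source may hold more compounds than are shown below. What is called first, only, known or untested is meant among the compounds shown, and "the series" means these compounds.

In a functional assay on SGC-7901 cells (Homo sapiens) for antiproliferative activity, read by MTT assay, with a stated time of 24 h (on this read-out higher numbers stand for weaker inhibition and lower numbers for stronger inhibition), compound 1 `Cc1cccc(NNC(=O)c2ccccc2NS(=O)(=O)c2cnc(O)nc2O)c1` gives > 20000 nM, which is a limit and not a number. Compound 2 `O=C(NNc1ccccc1Cl)c1ccccc1NS(=O)(=O)c1cnc(O)nc1O` gives > 20000 nM, which is also a limit. Among the measured compounds shown here, compound 3 `Cc1ccccc1C(=O)NNC(=O)c1ccccc1NS(=O)(=O)c1cnc(O)nc1O` gives 13000 nM, the only true number so far. The other two results share one ceiling: the limit of > 20000 nM in this assay, at which 2 of the 3 values shown sit.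

Compound 4 `Cc1ccc(C(=O)NNC(=O)c2ccccc2NS(=O)(=O)c2cnc(O)nc2O)cc1` is the next entry, and it differs from compound 3 in one place: 4-methylphenyl in place of 2-methylphenyl on a carbonyl carbon. The change puts 4-methylphenyl in place of 2-methylphenyl on a carbonyl carbon, with the same atoms joined differently.

Two measured steps lead to compound 3: an at least 1.5-fold lower number from compound 1 to compound 3 (0.18 log units; that floor lies within the scatter) and an at least 1.5-fold lower number from compound 2 to compound 3 (0.18 log units; that floor lies within the scatter). Both are floors that lie within the scatter, and both exchange the group on an amine nitrogen. The remaining step, a step that the two limits leave unreadable from compound 1 to compound 2, cannot be read. None of the three exchanges one methylphenyl for another on a carbonyl carbon, so the data give no direction for this change. No step beyond the scatter is therefore expected in this assay, in either direction, and the expectation stays anchored on compound 3 at 13000 nM. The estimated step is a 1.1-fold higher number from compound 3 to compound 4 (0.03 log units; within the scatter). Compound 4 is expected at 14000 nM, with an estimated range of 6500 nM to 20000 nM. A result reported only as a limit remains possible.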

Compound 4, half-maximal inhibitory concentration: 15500 nM
The estimate for compound 4 lay 1.1-fold (0.04 log units) below the measured number; the range from low to high includes it.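

In this assay, 4-methylphenyl in place of 2-methylphenyl on a carbonyl carbon gives a 1.2-fold higher number from compound 3 to compound 4 (0.08 log units; within the scatter), so this first reading of the exchange does not separate the two methylphenyl groups. With (4-methylphenyl)carbonyl on the amine nitrogen, the exchanges from the two earlier compounds read an at least 1.2-fold lower number from compound 2 to compound 4 (0.11 log units; that floor lies within the scatter) and an at least 1.2-fold lower number from compound 1 to compound 4 (0.11 log units; that floor lies within the scatter), and these floors stay within the scatter, as those for compound 3 do. Compounds 1 and 2 remain limits and not numbers: the limit of > 20000 nM in this assay, at which 2 of the 4 values shown sit.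

The compounds shown leave open whether any group on this carbonyl carbon can move the number beyond the scatter, as only the two methylphenyl groups are compared there. A longer chain or a phenyl group carrying a carboxylic acid on the same carbonyl carbon would put that question to the series, while the true size of the steps from compound 1 and compound 2 stays unread.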